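Vero cytotoxicity notes: difluorophenyl carbinol analogue of compound 1

The source may report more compounds than this note shows. Statements on the series, on what has been measured and on what is new or still open speak of the compounds shown alone.

Measured compounds:
compound 1 `COc1ncc(-c2ccccc2)cc1[C@@H](c1ccccc1)[C@@](O)(CCN(C)C)c1ccccc1` — > 50 ug/mL
compound 2 `COc1nc(C(C)(C)C)ccc1[C@@H](c1ccccc1)[C@@](O)(CCN(C)C)c1cccc2ccccc12` — 27.6 ug/mL
compound 3 `COc1nc(-c2ccc(Cl)c(F)c2)ccc1[C@@H](c1ccccc1)[C@@](O)(CCN(C)C)c1cccc2ccccc12` — > 50 ug/mL

In a toxicity assay on Vero cells (Chlorocebus sabaeus) for cytotoxicity (on this read-out lower numbers stand for higher toxicity in this test and higher numbers for lower toxicity in this test), compound 1 gives > 50 ug/mL, which is a limit of the assay and not a number. Compound 3 likewise gives only a limit, > 50 ug/mL. Compound 2 gives 27.6 ug/mL. For the measured compounds named here, the single measured step, an at least 1.8-fold higher number from compound 2 to compound 3 (0.25 log units; that floor lies within the scatter), concerns a group on an aromatic carbon of the core, a different place from the change considered here.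

Compound 4 `COc1ncc(-c2ccccc2)cc1[C@@H](c1ccccc1)[C@@](O)(CCN(C)C)c1cc(F)ccc1F` differs from compound 1 by 2,5-difluorophenyl in place of phenyl on a saturated chain carbon bound to an oxygen on a saturated carbon and two saturated chain carbons. Going by the values given here, no measured step touches this position, so no direction can be read from the series; what is known is that two of the three values sit at the limit (the limit of > 50 ug/mL in this assay, at which 2 of the 3 values shown sit). Compound 4 is therefore expected to remain near that limit, estimated at 50 ug/mL with a range of 20 ug/mL to 100 ug/mL, an expected step of a number no higher from compound 1 to compound 4 (the limit leaves the size open).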

Compound 4, half-maximal cytotoxic concentration: > 50 ug/mL
Compound 4: no number, only a limit; the forecaster's own chance of this, stated with the estimate: 60%; the middle value sits exactly at the limit.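

For the compounds shown here, compound 1 and compound 4 each give only a limit of the assay in this assay, so no step between them can be read. The compounds shown leave open whether 2,5-difluorophenyl in place of phenyl changes the number at all: the limit of > 50 ug/mL in this assay, at which 3 of the 4 values shown sit.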